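Swapping a Selenium Group for Methoxy on Compound 3

The compounds below may be only part of what the source reports. "The series", "measured", "known", "first", "only" and "open" are said of these compounds alone.

Compound 1 `COc1ccc(CNc2nc([SeH])nc3ccccc23)cc1` gives 60900 nM in a functional assay on HTB-54 cells (Homo sapiens) for cytotoxicity, read by MTT assay, with a stated time of 72 h; a higher number here means a weaker inhibitor of growth, a lower number a stronger inhibitor of growth. Compound 2 `CCCCCSc1nc(NCc2ccc([Se]C)cc2)c2ccccc2n1` gives 50000 nM in this assay. Compound 3 `CSc1nc(NCc2ccc([Se]C)cc2)c2ccccc2n1` reaches only the limit > 100000 nM in this assay.

Compound 3 is thus known only as a limit, so where it stands among these numbers cannot be told beyond that. For the measured compounds named here, the one measured step that leads to it, an at least 2.0-fold higher number from compound 2 to compound 3 (0.30 log units; that floor lies within the scatter), ends at that same limit (the limit of > 100000 nM in this assay, at which 1 of the 3 values shown sits), so its true size is also open. Compound 4 `COc1ccc(CNc2nc(SC)nc3ccccc23)cc1` differs from compound 3 by a group of 2 heavy atoms (1 carbon, 1 oxygen; no ring) in place of a group of 2 heavy atoms (1 carbon, 1 selenium; no ring), on an aromatic carbon. Going by the values given here, no measured step makes this exchange; compound 1 carries the same methoxy on its own core and gives a weak number. A step within the scatter is expected, an at least 1.1-fold lower number from compound 3 to compound 4 (0.04 log units; that floor lies within the scatter), with the direction open. Compound 4 is estimated at 90000 nM, between 40000 nM and 200000 nM, with a fair chance that this assay again reports only a limit.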

Compound 4, concentration for total growth inhibition: > 100000 nM
Compound 4: a limit, no number; the forecaster's own chance of this, stated with the estimate: 45%; at least 1.1-fold (0.04 log units) between middle value and limit.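

In this assay compound 4 reaches only a limit, > 100000 nM. Compound 3 is also a limit, so the steps between the two cannot be read, and the methoxy and selenium groups on this aromatic carbon, para to a large group, end at the same limit: the limit of > 100000 nM in this assay, at which 2 of the 4 values shown sit. Changing the selenium atom on the shared core to the sulfur group gives an at least 1.6-fold higher number from compound 1 to compound 4 (0.21 log units; that floor lies within the scatter), a floor that stays within the usual scatter, so this change shows no clear effect so far.

As far as these compounds go, the true values of compound 3 and compound 4 remain unknown, and with them any real difference between methoxy and the selenium group. Also open, from the compounds shown here alone, is how this position would read with an amine in the same place, at a level of growth inhibition that gives a number rather than a limit.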